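Replacing furan-2-yl with iodo in compound 1

This account rests on a few compounds, and the source may have more. Where it says the series, first, only, none or still open, it means among the compounds named here.

Among the measured compounds shown here, in a functional assay on HCT-116 cells (Homo sapiens), read by MTT assay, with a stated time of 72 h (a lower number here means a stronger inhibitor, a higher number a weaker inhibitor), compound 1 (`CNc1ncnc2c1c(-c1ccco1)cn2[C@@H]1O[C@H](CO)[C@@H](O)[C@H]1O`) gives 440 nM, the only actual number among the three results in hand. Compound 2 (`C#Cc1cn([C@@H]2O[C@H](CO)[C@@H](O)[C@H]2O)c2nc(C)nc(N)c12`) reads > 20000 nM, which is a limit of the assay and not a number. Compound 3 (`COc1nc(N)nc2c1c(-c1ccccc1)cn2[C@@H]1O[C@H](CO)[C@@H](O)[C@H]1O`) reads > 20000 nM, which is likewise a limit. These two results make up most of the picture, as the limit of > 20000 nM in this assay, at which 2 of the 3 values shown sit, shows. For the measured compounds named here, compound 1 is therefore the one compound with a measured potency, and it sits well clear of that limit.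

The next compound to be tested, compound 4 (`CNc1ncnc2c1c(I)cn2[C@@H]1O[C@H](CO)[C@@H](O)[C@H]1O`), keeps the core of compound 1 and changes one place. It carries iodo in place of furan-2-yl on an aromatic carbon of a five-membered aromatic ring with 1 nitrogen (iodo in place of furan-2-yl on an aromatic carbon). Going by the values given here, no measured pair in this small set isolates a change at that place, so the judgement rests on compound 1 at 440 nM alone, and it must stay broad. A moderate loss in this assay is expected, rather than a fall to the limit, although a result close to compound 1 would not surprise. The expected change is a 2.0-fold higher number from compound 1 to compound 4 (0.31 log units; beyond the scatter). For compound 4 the estimate is 900 nM, with an expected range from 100 nM to 8000 nM.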

Compound 4, half-maximal inhibitory concentration: > 100000 nM
Compound 4: only a limit was reported (the forecaster's own chance of this, stated with the estimate: 10%); middle value at least 110-fold (2.04 log units) away from the limit.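

In this assay, among the compounds shown here, replacing furan-2-yl with iodo on an aromatic carbon of the five-membered aromatic ring with 1 nitrogen gives an at least 220-fold higher number from compound 1 to compound 4 (2.35 log units; beyond the scatter), the first change at this place that can be read in the set. Compound 4 reads > 100000 nM, which is a limit of the assay and not a number, so the step gives only a lower bound on the size of the change: the limit of > 100000 nM in this assay, at which 1 of the 4 values shown sits. This shows that the place is far from indifferent on this core, since the five-membered aromatic ring of furan-2-yl goes with a measured potency and the single heavy atom of iodo goes with none that the assay can report.

With only these two groups compared at this place, the result cannot say whether the ring as a whole, its oxygen or simply the number of heavy atoms accounts for the step, and a thiophen-2-yl ring, a plain methyl or an aminomethyl group on the same carbon would help to separate these. For the compounds shown here, compounds 2 and 3 differ from compound 1 in more than one place, so no steps to them can be read and they add nothing on this question.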